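Swapping one pyridine ring for another on a shared core

The source may hold more compounds than are shown below. What is called first, only, known or untested is meant among the compounds shown, and "the series" means these compounds.

In a functional assay on the whole organism (liver, strain NMRI) for inhibition, with Mus musculus as the target, with a stated time of 3 h, at a dose of 3 mg/kg by the oral route (a higher number here means more inhibition at the dose given (going by the name of the read-out), a lower number less inhibition), compound 1 `O=[N+]([O-])c1cc(-c2cc(-c3ccccn3)no2)cc(O)c1O` gives 27.5%, and compound 2 `Cc1ccc(-c2cc(-c3cc(O)c(O)c([N+](=O)[O-])c3)on2)c(Cl)n1` gives 21.6%, the lower of the two numbers, with compound 1 its nearest neighbour: a number 5.9 percentage points lower from compound 1 to compound 2 (within the scatter). Compound 3 `O=[N+]([O-])c1cc(-c2cc(-c3ccnc(F)c3)no2)cc(O)c1O` differs from compound 2 in one place: 2-fluoropyridin-4-yl in place of 2-chloro-6-methylpyridin-3-yl on an aromatic carbon. Among the measured compounds shown here, the only measured step that bears on this, the exchange of one pyridine ring for another, is the step from compound 1 to compound 2, which stayed within the scatter. No step beyond the scatter is therefore expected for compound 3, whose estimated result is 25% within 10% to 40%, that is a number 3.4 percentage points higher from compound 2 to compound 3 (within the scatter).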

Compound 3, a percentage reported as inhibition, in the whole organism at one dose (the size of the read-out at that dose, not a potency): 18.7%
Beside the measured number, compound 3's estimate is 6.3 percentage points above it, and the stated range covers the measured number.
By their numbers in this assay, from the lowest: compounds 3, 2 and 1 (each within the scatter of the next).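

With 2-fluoropyridin-4-yl at this position, the result is a number 2.9 percentage points lower from compound 2 to compound 3 (within the scatter), and against the unsubstituted pyridin-2-yl it is a number 8.8 percentage points lower from compound 1 to compound 3 (within the scatter). The three pyridine rings, whether they carry chlorine and methyl, fluorine or nothing, therefore cannot be told apart at this position by these numbers. Nothing available explains why these rings give such similar results. All the compounds shown keep a pyridine ring here, so it remains open whether a different group, such as an amine or a carboxylic acid, would give a step beyond the scatter.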